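Methyl on the ring carbon: compound 3 to compound 4

The source may report more compounds than this note shows. Statements on the series, on what has been measured and on what is new or still open speak of the compounds shown alone.

Compound 1 `COc1ccccc1-c1cc(O)c2cc(C)cnc2n1` gives 30900 nM in a functional assay on SF-295 cells (Homo sapiens); a higher number here means a weaker inhibitor of growth, a lower number a stronger inhibitor of growth.
Compound 2 `Cc1cc(C)c2c(O)cc(-c3ccc(Cl)cc3)nc2n1` gives 16200 nM in this assay.
Compound 3 `COc1ccccc1-c1cc(O)c2cccnc2n1` gives 23400 nM in this assay.

Compound 3 stands second highest of the three numbers; its nearest neighbour is compound 1, and compound 2 lies furthest from it, yet both gaps are within the scatter, so no order among the three can be read from them. Compound 4 `COc1ccccc1-c1cc(O)c2ccc(C)nc2n1` differs from compound 3 in one place: methyl in place of hydrogen on an aromatic carbon. Among the compounds with values here, one measured step bears on this kind of change, the step from compound 1 to compound 3, in which a methyl on an aromatic carbon of the shared core was exchanged for hydrogen: a 1.3-fold lower number from compound 1 to compound 3 (0.12 log units; within the scatter). That step did not move the number beyond the scatter, so a methyl entering at another aromatic carbon of the same core is expected to do little as well. Compound 4 is therefore estimated at 23000 nM in this assay, with a range of 10000 nM to 50000 nM, which means an expected step of a 1.0-fold lower number from compound 3 to compound 4 (0.01 log units; within the scatter).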

Compound 4, concentration for 50% growth inhibition: > 100000 nM
Compound 4: a limit, no number (the forecaster's own chance of this, stated with the estimate: 5%); middle value at least 4.3-fold (0.63 log units) from the limit.
By their numbers in this assay, from the lowest: compounds 2, 3 and 1 (each within the scatter of the next). At a limit, above all of these: compound 4.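

The methyl next to the ring nitrogen did what the earlier methyl had not: it moved the number beyond the scatter, an at least 4.2-fold higher number from compound 3 to compound 4 (0.63 log units; beyond the scatter). Within the data shown here, the only earlier step of this kind, a 1.3-fold lower number from compound 1 to compound 3 (0.12 log units; within the scatter), stayed within the scatter, so the same exchange of hydrogen and methyl on an aromatic carbon of the shared core does not carry the same weight at every carbon. The reading for compound 4 in this assay is a limit and not a number, so the step gives only a minimum size: the limit of > 100000 nM in this assay, at which 1 of the 4 values shown sits.

From the compounds shown here alone, how far compound 4 lies beyond that limit stays open, and this single pair cannot show whether the change would act alike with another group on the other ring. Nor do the compounds shown tell whether an ethyl, a chlorine, a methoxy or an amine on this carbon would behave as the methyl does.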